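Swapping a Naphthyl Thiourea for a Pyridyl One

The source may report more compounds than this note shows. Statements on the series, on what has been measured and on what is new or still open speak of the compounds shown alone.

Of the compounds shown here, two built on the same core have been tested in a functional assay on HeLa cells (Homo sapiens) for antiproliferative activity, with a stated time of 24 h; a higher number here means a weaker inhibitor, a lower number a stronger inhibitor. Compound 1, `Cc1ccc(C(=O)Nc2sc3c(c2C(N)=O)CCN(Cc2ccc(Cl)cc2Cl)C3)cc1`, gives only a limit of > 50000 nM in this assay, so no number is known for it. Among the measured compounds shown here, compound 2, `NC(=O)c1c(NC(=O)c2ccccc2Cl)sc2c1CCN(C(=S)Nc1cccc3ccccc13)C2`, gives 30800 nM in this assay, which is the only actual number in the set. The entry for compound 1 is a limit rather than a number, as the limit of > 50000 nM in this assay, at which 1 of the 2 values shown sits, records. Even so, compound 2 is a weak inhibitor on this scale.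

Compound 3, `NC(=O)c1c(NC(=O)c2ccccc2Cl)sc2c1CCN(C(=S)Nc1cccnc1)C2`, is still to be measured in this assay. It differs from compound 2 in one place: pyridin-3-yl in place of naphthalen-1-yl on an amide-type nitrogen. The group that leaves, naphthalen-1-yl, is replaced by the smaller pyridin-3-yl on the same amide-type nitrogen of the thiocarbonyl.

For the measured compounds named here, no measured step of this kind is available to guide the expectation. The step from compound 2 to compound 3 is expected to be modest, with a 1.3-fold higher number from compound 2 to compound 3 (0.11 log units; within the scatter) leaning toward weaker inhibition rather than stronger. Compound 3 is therefore estimated at 40000 nM, within a range from 10000 nM to 100000 nM.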

Compound 3, half-maximal inhibitory concentration: > 50000 nM
Compound 3 gave a limit, no number; the forecaster's own chance of this, stated with the estimate: 45%; at least 1.2-fold (0.09 log units) between middle value and limit.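

Placing pyridin-3-yl in place of naphthalen-1-yl on the amide-type nitrogen gives the first step read at this position, in this assay: an at least 1.6-fold higher number from compound 2 to compound 3 (0.21 log units; that floor lies within the scatter). This figure is only a floor and it lies within the scatter, so it does not establish a real loss of activity, but it does show that this swap brings no gain in strength that the assay can detect. For compound 3 the entry is a limit and not a number, and the set now holds more limits than actual numbers: the limit of > 50000 nM in this assay, at which 2 of the 3 values shown sit.

What stays open is which part of the swap matters, as it takes away one of the two aromatic rings and brings in a ring nitrogen at the same time, and the compounds shown do not separate these two changes. A phenyl group on the same nitrogen would keep a single ring of carbon only, and a quinolin-3-yl group would keep two rings along with a ring nitrogen, so either one would pull the two changes apart.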